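The source may hold more compounds than are shown below. What is called first, only, known or untested is meant among the compounds shown, and "the series" means these compounds.

Within the data shown here, in a functional assay on cells (Cancer cell lines, Homo sapiens) for inhibition, read by MTT assay, with a stated time of 48 h (on this read-out higher numbers stand for weaker inhibition and lower numbers for stronger inhibition), compound 2 `O=C(/C=C/c1ccccc1[N+](=O)[O-])NNC(=O)c1ccc2c(c1)OCCO2` gives 890 nM, the lower of the two numbers so far, while compound 1 `COc1ccccc1/C=C/C(=O)NNC(=O)c1ccc2c(c1)OCCO2` gives 8060 nM. In compound 3 `COc1ccc(/C=C/C(=O)NNC(=O)c2ccc3c(c2)OCCO3)cc1`, 4-methoxyphenyl stands in place of 2-nitrophenyl: 4-methoxyphenyl in place of 2-nitrophenyl on a double-bonded chain carbon bound to a double-bonded chain carbon. Among the measured compounds shown here, one measured step bears on this change, the modest 9.1-fold lower number from compound 1 to compound 2 (0.96 log units; beyond the scatter), with nitro in place of methoxy on an aromatic carbon. For the measured compounds named here, compound 3 also has methoxy rather than nitro, so a step of similar size to a higher number is expected in this assay, although no measured pair tests where the methoxy sits. The expected change is a 5.6-fold higher number from compound 2 to compound 3 (0.75 log units; beyond the scatter). For compound 3 the estimated value is 5000 nM, within 1500 nM to 16000 nM.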

Compound 3, half-maximal inhibitory concentration: 930 nM
The estimate for compound 3 lay 5.4-fold (0.73 log units) above the measured number; the measured number lies below the stated range.
By their numbers in this assay, from the lowest: compounds 2 and 3 (each within the scatter of the next); then compound 1.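

In this assay, 4-methoxyphenyl and 2-nitrophenyl on this double-bonded chain carbon cannot be told apart, with a 1.0-fold higher number from compound 2 to compound 3 (0.02 log units; within the scatter), so a methoxy group does not by itself go with the higher number. Among the methoxy compounds, 4-methoxyphenyl in place of 2-methoxyphenyl gives an 8.7-fold lower number from compound 1 to compound 3 (0.94 log units; beyond the scatter), so the place of the methoxy on the phenyl ring counts, not just its presence. No evidence on hand accounts for this difference.

Open, going by these compounds, is whether 4-nitrophenyl would match compound 3 or differ from it. Also open, on these data alone, is how a phenyl ring carrying an amine or a carboxylic acid would read at this position.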